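Extending the Aryl Group on a Shared Core

The source may hold more compounds than are shown below. What is called first, only, known or untested is meant among the compounds shown, and "the series" means these compounds.

The measured set begins with compound 1 `COc1ccc(Nc2cc(C(C)C)oc(=O)c2)cc1`, which in a functional assay on DU-145 cells (Homo sapiens) for cytotoxicity, read by MTT assay, with a stated time of 72 h (a lower number here means that less compound is needed, a higher number that more compound is needed for the effect), gives only a limit, > 30 uM. Compound 2 `COc1ccc(Nc2cc(-c3ccccc3)oc(=O)c2)cc1` gives 0.12 uM in this assay, and compound 3 `COc1ccc(Nc2cc(-c3ccc4ccccc4c3)oc(=O)c2)cc1` gives 0.15 uM. Compound 2 therefore holds the lowest of the two numbers, with compound 3 within the scatter of it. For the measured compounds named here, the one measured single-point step, an at least 250-fold lower number from compound 1 to compound 2 (2.39 log units; beyond the scatter), was large, with compound 1 sitting at the limit of > 30 uM in this assay, at which 1 of the 3 values shown sits. Compound 4 `COc1ccc(Nc2cc(/C=C/c3ccccc3)oc(=O)c2)cc1` differs from compound 2 by 2-phenylethenyl in place of phenyl on an aromatic carbon. This again enlarges the aromatic group while keeping its ring, as compound 3 does beside compound 2 with values within the scatter of each other, so a step within the scatter is expected, a 1.3-fold higher number from compound 2 to compound 4 (0.10 log units; within the scatter). Compound 4 is thus estimated at 0.15 uM, with a range from 0.05 uM to 0.5 uM.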

Compound 4, concentration for half-maximal effect: 0.11 uM
Compound 4: the middle estimate sits 1.4-fold (0.13 log units) above what was measured; measured number inside the range.
By their numbers in this assay, from the lowest: compounds 4, 2 and 3 (each within the scatter of the next). At a limit, above all of these: compound 1.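

In this assay, the position next to the ring oxygen also accepts 2-phenylethenyl, which adds a double bond outside aromatic rings and sets the phenyl ring further out, with no change that can be told from phenyl: a 1.1-fold lower number from compound 2 to compound 4 (0.04 log units; within the scatter). Against isopropyl the difference is again large: an at least 270-fold lower number from compound 1 to compound 4 (2.43 log units; beyond the scatter). That step starts from a limit and not from a number: the limit of > 30 uM in this assay, at which 1 of the 4 values shown sits.

Whether the double bond matters remains open, as 2-phenylethyl is not among the compounds shown. So does whether an amine or a longer open carbon chain at this position would give similarly low numbers.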